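Swapping the aryl on the sulfonyl sulfur toward a pyridine

A few compounds are considered here, and "the series" means these few. Any claim that something is new, unique, unknown or untested is made for them only; others in the source may bear on it.

Measured compounds:
compound 1 `O=C(NCc1ccc(CNS(=O)(=O)c2cccc3ccccc23)cc1)c1ccc(CNc2ncccn2)cc1` gives 1000 nM
compound 2 `Cc1ccc(S(=O)(=O)NCc2ccc(CNC(=O)c3ccc(CNc4ncccn4)cc3)cc2)cc1` gives 100 nM
compound 3 `Cc1ccccc1S(=O)(=O)NCc1ccc(CNC(=O)c2ccc(CNc3ncccn3)cc2)cc1` gives 10 nM

In an assay on MDA-MB-231 cells for binding affinity to C-X-C chemokine receptor type 4 (Homo sapiens), read by microscopy, with stated times of 10 min and 30 min (a higher number here means that more compound is needed for the effect, a lower number that less compound is needed), compound 3 stands lowest of the three, with compound 2 nearest and compound 1 furthest. Compound 4 `O=C(NCc1ccc(CNS(=O)(=O)c2cccnc2)cc1)c1ccc(CNc2ncccn2)cc1` is not yet measured; it differs from compound 3 only on the sulfonyl sulfur: pyridin-3-yl in place of 2-methylphenyl on a sulfonyl sulfur. The measured steps that bear on this place are a 10-fold lower number from compound 2 to compound 3 (1.00 log units; beyond the scatter) and a 100-fold lower number from compound 1 to compound 3 (2.00 log units; beyond the scatter): every aryl group tried there other than 2-methylphenyl gave a higher number. Pyridin-3-yl has no measured counterpart, so the direction rests on that pattern alone. Compound 4 is expected to give a higher number than compound 3, estimated as a 10-fold higher number from compound 3 to compound 4 (1.00 log units; beyond the scatter). Compound 4 is therefore estimated at 100 nM, within a range from 20 nM to 1000 nM.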

Compound 4, effective concentration (reported as EC, without a stated level of effect): > 1000 nM
Compound 4 was reported as a limit; the forecaster's own chance of this, stated with the estimate: 10%; middle value at least 10-fold (1.00 log units) away from the limit.
By their numbers in this assay, from the lowest: compound 3; then compound 2; then compound 1.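

In this assay compound 4 is reported only as a limit, > 1000 nM. Up to now only carbon-only aromatic rings had stood on the sulfonyl sulfur, and pyridin-3-yl, with a ring nitrogen, shows that this place can lose far more than the methyl shift did: the result is an at least 100-fold higher number from compound 3 to compound 4 (2.00 log units; beyond the scatter), and an at least 10-fold higher number from compound 2 to compound 4 (1.00 log units; beyond the scatter). Against naphthalen-1-yl the data give only a number no lower from compound 1 to compound 4 (the limit leaves the size open).

Pyridin-3-yl differs from 2-methylphenyl in both the ring nitrogen and the missing methyl, so which of the two matters stays open. Plain phenyl or 2-methylpyridin-3-yl on the sulfonyl sulfur would separate them.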